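A few compounds are considered here, and "the series" means these few. Any claim that something is new, unique, unknown or untested is made for them only; others in the source may bear on it.

Measured in a functional assay on L5178Y cells (Mus musculus) for inhibition, read by MTT assay, with a stated time of 24 h; on this read-out lower numbers stand for stronger inhibition and higher numbers for weaker inhibition:
Compound 1 `COc1cc(O)c2c(c1)O[C@H](c1ccc(O)cc1)C/C2=N\Nc1ccccc1`: >= 11300 nM
Compound 2 `COc1cc(O)c2c(c1)O[C@H](c1ccc(O)cc1)C/C2=N\Nc1ccc(Br)cn1`: 4300 nM
Compound 3 `COc1cc(O)c2c(c1)O[C@H](c1ccc(O)cc1)C/C2=N\NC(=O)c1cccs1`: 9400 nM
Compound 4 `COc1cc(O)c2c(c1)O[C@H](c1ccc(O)cc1)C/C2=N\NC(=O)c1ccc(N)cc1`: not yet measured

Compound 1 gives >= 11300 nM, which is a limit of the assay. Compound 3, at 9400 nM, holds the higher of the two actual numbers. Compound 4 carries 4-aminophenyl in place of thiophen-2-yl on a carbonyl carbon. For the measured compounds named here, no measured step makes this exact exchange. The nearest are changes on the amine nitrogen: a 2.2-fold higher number from compound 2 to compound 3 (0.34 log units; beyond the scatter), a modest step, and an at least 1.2-fold lower number from compound 1 to compound 3 (0.07 log units; that floor lies within the scatter), whose floor lies within the scatter. With only these to go on, the expected 1.2-fold lower number from compound 3 to compound 4 (0.07 log units; within the scatter) in this assay is estimated to stay within the scatter. For compound 4 the estimated value is 8000 nM, with an expected range of 3500 nM to 18000 nM.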

Compound 4, half-maximal inhibitory concentration: >= 11300 nM
Compound 4: a limit, no number (the forecaster's own chance of this, stated with the estimate: 25%); middle value at least 1.4-fold (0.14 log units) from the limit.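

In this assay compound 4 gives >= 11300 nM, a limit of the assay and not a number. Placing 4-aminophenyl on the carbonyl carbon in place of thiophen-2-yl gives an at least 1.2-fold higher number from compound 3 to compound 4 (0.07 log units; that floor lies within the scatter), so this exchange is not shown to have any effect, while (4-aminophenyl)carbonyl on the amine nitrogen in place of 5-bromopyridin-2-yl gives an at least 2.6-fold higher number from compound 2 to compound 4 (0.41 log units; beyond the scatter). The step between compound 1 and compound 4 cannot be read: the limit of >= 11300 nM in this assay, at which 2 of the 4 values shown sit.

From the compounds shown here alone, how far the true value of compound 4 lies from its limit stays open. Going by these compounds, it is also open whether a hydroxyl or a nitrile in place of the amino group of 4-aminophenyl would lower the number.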